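Huh-7 cytotoxicity across a fluoro-to-methoxy and cyclopropyl-to-methyl set

A few compounds are considered here, and "the series" means these few. Any claim that something is new, unique, unknown or untested is made for them only; others in the source may bear on it.

Compound 1 `Cc1ccc2nc([C@H](CC3CCN(C(=O)C(C)C)CC3)N3C(=O)CN(c4ccc(Oc5ccc(F)cc5)cc4)C3=O)n(C3CC3)c2c1`, compound 2 `COc1ccc(Oc2ccc(N3CC(=O)N([C@@H](CC4CCN(C(=O)C(C)C)CC4)c4nc5ccc(C)cc5n4C4CC4)C3=O)cc2)cc1` and compound 3 `Cc1ccc2nc([C@H](CC3CCN(C(=O)C(C)C)CC3)N3C(=O)CN(c4ccc(Oc5ccc(F)cc5)cc4)C3=O)n(C)c2c1` have been tested in an ADME assay on Huh-7 cells (Homo sapiens) for cytotoxicity, read by MTT assay; on this read-out lower numbers stand for stronger inhibition and higher numbers for weaker inhibition. Compound 1 reaches only the limit of the assay, > 100000 nM, and not a number. Compound 2 likewise gives only a limit, > 100000 nM. Compound 3 also stops at a limit, > 100000 nM. The change from compound 1 to compound 2 is methoxy in place of fluoro on an aromatic carbon; the step that the two limits leave unreadable from compound 1 to compound 2. The cores of compound 1 and compound 3 differ by methyl in place of cyclopropyl on an aromatic nitrogen, and the step that the two limits leave unreadable from compound 1 to compound 3. Among the compounds with values here, all three values sit at one point, (the limit of > 100000 nM in this assay, at which 3 of the 3 values shown sit), so no step in this set can be read.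

Compound 4 `COc1ccc(Oc2ccc(N3CC(=O)N([C@@H](CC4CCN(C(=O)C(C)C)CC4)c4nc5ccc(C)cc5n4C)C3=O)cc2)cc1` is not yet measured. It differs from compound 3 by methoxy in place of fluoro on an aromatic carbon, the same change as from compound 1 to compound 2, at the same place. In this assay the step that the limit leaves unreadable from compound 3 to compound 4 is expected to be flat, resting on compound 1 and compound 2 both sitting at the limit (the limit of > 100000 nM in this assay, at which 3 of the 3 values shown sit). Compound 4 is expected to give 150000 nM, between 100000 nM and 300000 nM, most likely again only a limit.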

Compound 4, half-maximal inhibitory concentration: > 100000 nM
Compound 4: a limit, no number; the forecaster's own chance of this, stated with the estimate: 90%; the middle value does not contradict the limit.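

Compound 4 also gives only a limit in this assay, so the steps to it from compound 3 and from compound 2 cannot be read: the limit of > 100000 nM in this assay, at which 4 of the 4 values shown sit.

The compounds shown leave open whether methoxy in place of fluoro or methyl in place of cyclopropyl shifts the read-out in this assay at all.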